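Cytotoxicity of a thymidine urea series: compound 3 to 4

The source may report more compounds than this note shows. Statements on the series, on what has been measured and on what is new or still open speak of the compounds shown alone.

Measured so far in an ADME assay on MRC5 cells (Homo sapiens) for cytotoxicity; on this read-out higher numbers stand for lower toxicity in this test and lower numbers for higher toxicity in this test:
Compound 1, `Cc1cn([C@@H]2C[C@H](O)[C@@H](CNC(=O)Nc3ccc(Cl)cc3)O2)c(=O)[nH]c1=O`; in this assay compound 1 gives > 50000 nM, a limit of the assay.
Compound 2, `Cc1cn([C@@H]2C[C@H](O)[C@@H](CNC(=O)Nc3ccc(Br)cc3)O2)c(=O)[nH]c1=O`; in this assay compound 2 gives > 50000 nM, a limit of the assay.
Compound 3, `Cc1ccc2nc(-c3ccc(NC(=O)NC[C@H]4O[C@H](n5cc(C)c(=O)[nH]c5=O)C[C@@H]4O)cc3)sc2c1`; in this assay compound 3 gives > 50000 nM, a limit of the assay.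

Compound 3 thus stands at the upper limit of this assay, and the two other values shown sit at the same limit, as noted in the limit of > 50000 nM in this assay, at which 3 of the 3 values shown sit. The steps among the measured compounds are a step that the two limits leave unreadable from compound 1 to compound 2, a step that the two limits leave unreadable from compound 1 to compound 3 and a step that the two limits leave unreadable from compound 2 to compound 3, none of which can be read in size or direction, since both ends of each step are limits.

The next compound is compound 4, `Cc1cn([C@@H]2C[C@H](O)[C@@H](CNC(=O)Nc3ccc(OCc4cccc(Cl)c4)cc3)O2)c(=O)[nH]c1=O`. It differs from compound 3 in one place: (3-chlorobenzyl)oxy in place of 6-methyl-1,3-benzothiazol-2-yl on an aromatic carbon. The three measured steps bear on this change only in that every change so far within this series has left the value at the limit; none gives a readable size. The account therefore expects no step beyond the scatter, with compound 4 estimated at 60000 nM, in the range 30000 nM to 150000 nM. This estimate means a step that the limit leaves unreadable from compound 3 to compound 4 expected from compound 3 to compound 4, most likely again reported only as a limit.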

Compound 4, half-maximal cytotoxic concentration: > 50000 nM
Compound 4 gave a limit, no number (the forecaster's own chance of this, stated with the estimate: 85%); the middle value is on the limit's open side.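

In this assay compound 4 gives > 50000 nM, a limit of the assay and not a number. Its steps from compound 1, compound 2 and compound 3 cannot be read, because all four compounds sit at the same limit: the limit of > 50000 nM in this assay, at which 4 of the 4 values shown sit.

The compounds shown leave open whether any group at this place changes the read-out at all: none of them gives a number.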